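Swapping trifluoromethyl for methyl on the shared core

The compounds below may be only part of what the source reports. "The series", "measured", "known", "first", "only" and "open" are said of these compounds alone.

Measured so far:
Compound 1, `CN(C(=O)NC(=O)c1ccc(Cl)cc1Cl)c1nc(C(F)(F)F)c(C(=O)N/N=C/c2cccc(C(F)(F)F)c2)s1`: 10.7 ug/mL
Compound 2, `CN(C(=O)NC(=O)c1c(F)cccc1F)c1nc(C(F)(F)F)c(C(=O)N/N=C/c2cccc(C(F)(F)F)c2)s1`: 21.8 ug/mL

In a functional assay on MCF7 cells (Homo sapiens) for inhibition, read by MTT assay, with a stated time of 72 h (a lower number here means a stronger inhibitor, a higher number a weaker inhibitor), compound 2 gives 21.8 ug/mL, the higher of the two numbers shown; compound 1 is the only neighbour, and the one measured step, a 2.0-fold higher number from compound 1 to compound 2 (0.31 log units; beyond the scatter), came from exchanging the aryl group on a carbonyl carbon, a different part of the molecule.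

Compound 3, `Cc1nc(N(C)C(=O)NC(=O)c2c(F)cccc2F)sc1C(=O)N/N=C/c1cccc(C(F)(F)F)c1`, differs from compound 2 by methyl in place of trifluoromethyl on an aromatic carbon. Among the measured compounds shown here, no measured step touches this ring carbon, so nothing here shows which way such a change moves the number or how far. For the measured compounds named here, the only step on record concerns another position and cannot stand in for it. The expectation is therefore a step of no size beyond the scatter, a 1.0-fold higher number from compound 2 to compound 3 (0.00 log units; within the scatter), with a wide margin of doubt. Compound 3 is estimated at 22 ug/mL, in a range from 8 ug/mL to 60 ug/mL.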

Compound 3, half-maximal inhibitory concentration: 28.2 ug/mL
Beside the measured number, compound 3's estimate is 1.3-fold (0.11 log units) below it; low and high end bracket the measured number.
By their numbers in this assay, from the lowest: compound 1; then compounds 2 and 3 (each within the scatter of the next).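

In this assay the exchange of trifluoromethyl for methyl on this aromatic carbon gives a 1.3-fold higher number from compound 2 to compound 3 (0.11 log units; within the scatter) and so leaves the two compounds indistinguishable. Among the compounds shown here, this is the first reading at this ring carbon, and it shows that, with the 2,6-difluorophenyl group in place, the smaller methyl group serves as well as trifluoromethyl at this position in this cell assay. No supporting measurement bears on why the number holds here.

The compounds shown leave open whether the same exchange would also make so little difference alongside the 2,4-dichlorophenyl group of compound 1. They also leave open how this ring carbon would respond to a group of another kind, such as an amine, a carboxylic acid or a longer chain.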